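Iodine shifted around the benzyl ring of compound 1

A few compounds are considered here, and "the series" means these few. Any claim that something is new, unique, unknown or untested is made for them only; others in the source may bear on it.

Compound 1 `O=c1cc(CNCc2ccccc2I)oc2ccc(O)c(O)c12` is the reference point of this series. In an ADME assay on Huh-7 cells (Homo sapiens) for cytotoxicity (a higher number here means that more compound is tolerated, a lower number that less compound is tolerated), compound 1 gives 87300 nM. Compound 2 `Cc1ccccc1CNCc1cc(=O)c2c(O)c(O)ccc2o1` carries methyl in place of iodo and in this assay compound 2 gives 52200 nM; the step of a 1.7-fold lower number from compound 1 to compound 2 (0.22 log units; within the scatter) lies within the scatter, so compound 1 holds the higher of the two numbers without a real gap to compound 2. Compound 3 `O=c1cc(CNCc2cccc(F)c2)oc2ccc(O)c(O)c12` in this assay reaches only a limit, > 100000 nM, and reports no number (the limit of > 100000 nM in this assay, at which 1 of the 3 values shown sits).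

Compound 4 `O=c1cc(CNCc2cccc(I)c2)oc2ccc(O)c(O)c12` has not yet been tested. It differs from compound 1 by 3-iodophenyl in place of 2-iodophenyl on a saturated chain carbon bound to an amine nitrogen. Two measured steps likewise exchange a 2-substituted phenyl for a 3-substituted one: an at least 1.1-fold higher number from compound 1 to compound 3 (0.05 log units; that floor lies within the scatter) and an at least 1.9-fold higher number from compound 2 to compound 3 (0.28 log units; that floor lies within the scatter), both with floors inside the scatter. Given these, the chemist expects for compound 4 no step beyond the scatter in this assay, that is a 1.1-fold higher number from compound 1 to compound 4 (0.06 log units; within the scatter). Compound 4 is therefore estimated at about 100000 nM, between 45000 nM and 220000 nM, with a fair chance that only a limit is reported.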

Compound 4, half-maximal cytotoxic concentration: > 100000 nM
Compound 4: only a limit was reported; the forecaster's own chance of this, stated with the estimate: 45%; the middle value sits exactly at the limit.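

With the same atoms joined differently, 3-iodophenyl in place of 2-iodophenyl on a saturated chain carbon bound to an amine nitrogen gives an at least 1.1-fold higher number from compound 1 to compound 4 (0.05 log units; that floor lies within the scatter), and exchanging 2-methylphenyl for 3-iodophenyl at that place gives an at least 1.9-fold higher number from compound 2 to compound 4 (0.28 log units; that floor lies within the scatter), so neither step shows a real change in this assay. The step between compound 3 and compound 4 cannot be read, since both stand at a limit, which leaves iodo in place of fluoro on an aromatic carbon unresolved. The new point is that a 3-substituted phenyl now reads only as a limit with iodo as well as with fluoro, while compound 1 and compound 2 give numbers: the limit of > 100000 nM in this assay, at which 2 of the 4 values shown sit.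

From the compounds shown here alone, the actual numbers behind the limits of compound 3 and compound 4 stay open. So does the outcome in this assay for a phenyl ring carrying an amine or a carboxylic acid at this place.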